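Moving the Methyl Group on the Amide Aryl Ring

The source may hold more compounds than are shown below. What is called first, only, known or untested is meant among the compounds shown, and "the series" means these compounds.

Measured compounds in a functional assay on MCF7 cells (Homo sapiens) for antiproliferative activity, read by MTT assay, with a stated time of 48 h; a higher number here means a weaker inhibitor, a lower number a stronger inhibitor:
compound 1 `O=C(Nc1cccc(/C=C/C(=O)c2nc3ccccc3[nH]2)c1)c1ccccc1` gives 11200 nM;
compound 2 `O=C(Nc1cccc(/C=C/C(=O)c2nc3ccccc3[nH]2)c1)c1ccc(Cl)cc1` gives 8410 nM;
compound 3 `Cc1ccccc1C(=O)Nc1cccc(/C=C/C(=O)c2nc3ccccc3[nH]2)c1` gives 5870 nM.

Compound 3 has the lowest of the three numbers in this assay, but its gaps to compound 2 and compound 1 both lie within the usual scatter, so no ordering among the three can be claimed. Compound 4 `Cc1ccc(C(=O)Nc2cccc(/C=C/C(=O)c3nc4ccccc4[nH]3)c2)cc1` is unmeasured; its change from compound 3 is 4-methylphenyl in place of 2-methylphenyl on a carbonyl carbon. For the measured compounds named here, three measured steps bear on it. Adding a methyl to the aryl ring gave a 1.9-fold lower number from compound 1 to compound 3 (0.28 log units; within the scatter), adding a chloro gave a 1.3-fold lower number from compound 1 to compound 2 (0.12 log units; within the scatter), and exchanging one substituted aryl ring for another gave a 1.4-fold lower number from compound 2 to compound 3 (0.16 log units; within the scatter). Every one of these falls inside the scatter, so swapping one methylphenyl for another is expected to give no step beyond the scatter. The expected step is a 1.2-fold higher number from compound 3 to compound 4 (0.08 log units; within the scatter). Compound 4 is therefore estimated at 7000 nM, with a plausible range from 3500 nM to 14000 nM.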

Compound 4, half-maximal inhibitory concentration: 9690 nM
Beside the measured number, compound 4's estimate is 1.4-fold (0.14 log units) below it; low and high end bracket the measured number.
By their numbers in this assay, from the lowest: compounds 3, 2, 4 and 1 (each within the scatter of the next).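

Exchanging 2-methylphenyl for 4-methylphenyl on the carbonyl carbon gives a 1.7-fold higher number from compound 3 to compound 4 (0.22 log units; within the scatter) in this assay, so among these compounds, where the methyl sits on this ring makes no difference that can be told apart from ordinary assay noise. The 4-methylphenyl compound also stays close to its other two relatives: methyl in place of chloro gives a 1.2-fold higher number from compound 2 to compound 4 (0.06 log units; within the scatter), and methyl in place of hydrogen gives a 1.2-fold lower number from compound 1 to compound 4 (0.06 log units; within the scatter). Nothing available here offers an explanation for these small steps.

All four compounds carry only hydrogen, chloro or methyl on this ring. As far as these compounds go, it therefore remains open whether an amine, a carboxylic acid or a longer alkyl chain there would give a step beyond the scatter.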